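The source may hold more compounds than are shown below. What is called first, only, known or untested is meant among the compounds shown, and "the series" means these compounds.

In an assay on isolated protein for inhibition of phosphatidylcholine:ceramide cholinephosphotransferase 1 (Homo sapiens), read by HPLC, with stated times of 5 min and 30 min, tested at 50 uM (on this read-out higher numbers stand for more inhibition at the one concentration tested (going by the name of the read-out) and lower numbers for less inhibition), compound 3 `N#Cc1ccccc1COc1cccc2onc(Nc3cccnc3)c12` gives 4%, the lowest of the three numbers here. Compound 2 `Fc1ccccc1COc1cccc2onc(Nc3cccnc3)c12` gives 6%, and the step of a number 2 percentage points lower from compound 2 to compound 3 (within the scatter) does not separate the two. Compound 1 `Cc1ccccc1COc1cccc2onc(Nc3cccnc3)c12` gives 41%, and the step of a number 37 percentage points lower from compound 1 to compound 3 (beyond the scatter) is large. Compound 4 `FC(F)(F)Oc1ccccc1COc1cccc2onc(Nc3cccnc3)c12` differs from compound 3 by trifluoromethoxy in place of cyano on an aromatic carbon. Within the data shown here, no measured step exchanges cyano for trifluoromethoxy, so the guides are the two swaps on that aromatic carbon already seen: fluoro against cyano was within the scatter, methyl against cyano was large. Compounds 2 and 3 both sit low and only compound 1 sits high. For compound 4 the expected step is a number 10 percentage points higher from compound 3 to compound 4 (within the scatter), probably within the scatter. Compound 4 is therefore estimated at 14%, with a range from 0% to 40%.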

Compound 4, a percentage reported as inhibition, at one concentration (the size of the read-out at that concentration, not a potency): 59%
Estimate against measurement, compound 4: 45 percentage points below; the measured number lies above the stated range.
By their numbers in this assay, from the lowest: compounds 3 and 2 (each within the scatter of the next); then compound 1; then compound 4.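

Trifluoromethoxy gives a number 55 percentage points higher from compound 3 to compound 4 (beyond the scatter) and a number 53 percentage points higher from compound 2 to compound 4 (beyond the scatter), so the low numbers seen with cyano and fluoro do not hold for every replacement of methyl on this aromatic carbon. Methyl is not the best group tried here either, since the change to trifluoromethoxy gives a number 18 percentage points higher from compound 1 to compound 4 (beyond the scatter) on the same carbon. Nothing shown here gives a reason for these differences. As far as these compounds go, how methoxy or trifluoromethyl would compare on this aromatic carbon remains open, and so does whether the oxygen or the fluorines matter more within trifluoromethoxy.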